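The source may report more compounds than this note shows. Statements on the series, on what has been measured and on what is new or still open speak of the compounds shown alone.

Compound 1 `OCc1cn(Cc2cccc(Br)c2)c2ccccc12`: 28 nM
Compound 2 `CC(O)c1cn(Cc2ccc(Cl)cc2)c2ccccc12`: 25100 nM
Compound 3 `O=C(NC1CCCCC1)OCc1cn(Cc2ccc(Cl)cc2)c2ccccc12`: 20 nM

All three compounds were tested in a functional assay on NCI-H460 cells (Homo sapiens) for cytotoxicity, read by sulforhodamine B assay, with a stated time of 3 days; on this read-out higher numbers stand for weaker inhibition and lower numbers for stronger inhibition. Compound 2 has the highest number of the three, which makes it the weakest, and its gaps to compound 1 and to compound 3 both lie far beyond the usual scatter. These compounds differ from one another in more than one place, so those gaps cannot be pinned on any single group.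

The next compound, compound 4 `Cc1cn(Cc2ccc(Cl)cc2)c2ccccc12`, comes from compound 2 through one change: methyl in place of 1-hydroxyethyl on an aromatic carbon, two ring bonds from the ring nitrogen. The counted difference is methyl in place of 1-hydroxyethyl on an aromatic carbon. Going by the values given here, no pair of measured compounds shows this change on its own, so any forecast here is a judgement.

The forecast starts from compound 2 at 25100 nM. Nothing in the three measured compounds suggests that a methyl at this place would bring back low numbers like those of compound 1 and compound 3. In this assay, the expected result is no step beyond the scatter, and the estimated change is a 1.2-fold higher number from compound 2 to compound 4 (0.08 log units; within the scatter). For compound 4 the expected value is 30000 nM, with an estimated range from 8000 nM to 100000 nM.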

Compound 4, half-maximal inhibitory concentration: > 31600 nM
Compound 4 was reported as a limit; the forecaster's own chance of this, stated with the estimate: 35%; middle value at least 1.0-fold (0.02 log units) from the limit.
By their numbers in this assay, from the lowest: compounds 3 and 1 (each within the scatter of the next); then compound 2. At a limit, above all of these: compound 4.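

In this assay, compound 4 gives > 31600 nM, which is a limit of the assay and not a number. Going by these compounds alone, this is the first change seen on its own at this aromatic carbon, two ring bonds from the ring nitrogen: methyl in place of 1-hydroxyethyl gives an at least 1.2-fold higher number from compound 2 to compound 4 (0.10 log units; that floor lies within the scatter), and the hydrogen-bond donor and acceptor of 1-hydroxyethyl can leave without any return to low numbers like those of compound 1 and compound 3. The true size of the step stays unknown, and only its floor can be read, because the result for compound 4 stands at a limit: the limit of > 31600 nM in this assay, at which 1 of the 4 values shown sits.

The compounds shown leave open what an amine, a carboxylic acid or a longer chain such as propyl would do at this same place on the core. Compound 1 and compound 3 each differ from compound 2 in more than one place, and how much of their far lower numbers belongs to the group at this position, rather than to their other differences, remains unresolved.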